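This account rests on a few compounds, and the source may have more. Where it says the series, first, only, none or still open, it means among the compounds named here.

Measured so far in a functional assay on ECa-109 cells for inhibition, with ECa-109 cell line (Homo sapiens) as the target, read by sulforhodamine B assay; on this read-out higher numbers stand for weaker inhibition and lower numbers for stronger inhibition:
compound 1 `O=C1C=C(N2CCC2)C(=O)c2c1nc1n2[C@H]2OC[C@@H](O)[C@H]2OC1`, a limit only: > 16000 nM
compound 2 `O=C1C=C(NC2CCCCC2)C(=O)c2c1nc1n2[C@H]2OC[C@@H](O)[C@H]2OC1`, a limit only: > 16000 nM
compound 3 `O=C1C(N2CCCCC2)=CC(=O)c2c1nc1n2[C@H]2OC[C@@H](O)[C@H]2OC1`, a limit only: > 8000 nM

Compound 3 stands at the limit of > 8000 nM in this assay, at which 1 of the 3 values shown sits, so it gives no number, only a limit. Compounds 1 and 2 both stand at the limit of > 16000 nM in this assay, at which 2 of the 3 values shown sit. The next member, compound 4 `O=C1C(Nc2cccc(Cl)c2)=CC(=O)c2c1nc1n2[C@H]2OC[C@@H](O)[C@H]2OC1`, differs from compound 3 in one place: (3-chlorophenyl)amino in place of piperidin-1-yl on a double-bonded ring carbon. Going by the values given here, the only measured step, a step that the two limits leave unreadable from compound 1 to compound 2, changes the group on the same ring carbon but remains unreadable, so no step of known size bears on this change. With all three values at limits, compound 4 is expected to stay in the weak range; the step that the limit leaves unreadable from compound 3 to compound 4 is an estimate without a measured anchor. Compound 4 is estimated at 10000 nM, with a range from 2500 nM to 40000 nM.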

Compound 4, half-maximal inhibitory concentration: 3080 nM
The estimate for compound 4 lay 3.2-fold (0.51 log units) above the measured number, and the stated range covers the measured number.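

Going by these compounds alone, the replacement of piperidin-1-yl by (3-chlorophenyl)amino on a double-bonded ring carbon gives an at least 2.5-fold lower number from compound 3 to compound 4 (0.41 log units; beyond the scatter) in this assay, the first step with a readable size; the earlier step cannot be read. At this position, activity can therefore move past the limit seen for the piperidin-1-yl member. The true size of the step remains open on one side, as its starting point is a limit: the limit of > 8000 nM in this assay, at which 1 of the 4 values shown sits.

The ring and the chlorine enter together with the nitrogen-bound hydrogen, so their shares remain unseparated. Plain phenylamino and benzylamino on the same carbon would help to divide them.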